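The source may hold more compounds than are shown below. What is called first, only, known or untested is meant among the compounds shown, and "the series" means these compounds.

Compound 2 `COc1ccc(C2=C(c3cc(OC)c(OC)c(OC)c3)CC(O[SiH2]C(C)(C)C)C2=O)cc1[N+](=O)[O-]` gives in an ADME assay on DU-145 cells (Homo sapiens) for cytotoxicity, read by MTT assay, with a stated time of 72 h (on this read-out higher numbers stand for weaker inhibition and lower numbers for stronger inhibition), only a limit of > 100 ug/mL, not a number: it sits at the limit of > 100 ug/mL in this assay, at which 1 of the 3 values shown sits, and tells just that inhibition was too weak to register. Two related compounds do carry numbers. Compound 1 `COc1ccc(C2=C(c3cc(OC)c(OC)c(OC)c3)C(=O)C(OC(C)=O)C2)cc1F` gives 16 ug/mL, and compound 3 `COc1ccc(C2=C(c3cc(OC)c(OC)c(OC)c3)C(=O)C(OC(C)=O)C2)cc1Cl` gives 64 ug/mL. Within the data shown here, the single measured step between them is a 4.0-fold higher number from compound 1 to compound 3 (0.60 log units; beyond the scatter). Compound 4 `COc1ccc(C2=C(c3cc(OC)c(OC)c(OC)c3)CC(O)C2=O)cc1[N+](=O)[O-]` differs from compound 2 in one place: a hydrogen atom in place of a group of 5 heavy atoms (4 carbon, 1 silicon; no ring), on an oxygen on a saturated carbon. The measured step from a fluoro to a chloro substituent on an aromatic carbon concerns a different part of the molecule and a different kind of change, so it offers no direct guide for what happens when a silicon-containing group is swapped for a hydrogen atom on an oxygen on a saturated carbon. Because compound 2 stands at a limit, as the limit of > 100 ug/mL in this assay, at which 1 of the 3 values shown sits, shows, the size of the step to compound 4 cannot be read off a starting number either, and its direction is open. The expected step of an at least 2.5-fold lower number from compound 2 to compound 4 (0.39 log units; beyond the scatter) is therefore an estimate with wide uncertainty. Compound 4 is expected in this assay to give about 40 ug/mL, within a range from 10 ug/mL to 150 ug/mL.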

Compound 4, half-maximal inhibitory concentration: > 100 ug/mL
Compound 4 was reported as a limit; the forecaster's own chance of this, stated with the estimate: 35%; middle value at least 2.5-fold (0.39 log units) away from the limit.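

Among these compounds, compound 2 and compound 4 both give only a limit in this assay and not a number, and no step between them can be read. The compounds shown leave open whether a hydrogen atom in place of the group of 5 heavy atoms on that oxygen changes inhibition at all, and in which direction.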